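A few compounds are considered here, and "the series" means these few. Any claim that something is new, unique, unknown or untested is made for them only; others in the source may bear on it.

In an ADME assay on microsomes from liver (Homo sapiens) for metabolic stability (a lower number here means slower removal, a higher number faster removal of the compound), compound 1 `CCCOc1cncc2nnc(-c3cnn(C)c3-c3ccc(C(F)(F)F)cc3)n12` is reported only as a limit, > 300 mL/min/kg. Among the true numbers, compound 2 `Cn1ncc(-c2nn(C)c3ncnc(N4CCC4)c23)c1-c1ccc(C(F)(F)F)cn1` gives 33 mL/min/kg and compound 3 `Cn1ncc(-c2nn(C)c3ncnc(N4CCC4)c23)c1-c1ccc(C2CC2)cc1` gives 90 mL/min/kg, the higher of the two. Compound 4 `Cn1ncc(-c2nn(C)c3ncnc(N4CCC4)c23)c1-c1ccc(C2CC2)cn1` carries 5-cyclopropylpyridin-2-yl in place of 4-cyclopropylphenyl on an aromatic carbon, and the count of that swap reads (5-cyclopropylpyridin-2-yl in place of 4-cyclopropylphenyl on an aromatic carbon). Within the data shown here, the one measured step that bears on it is a 2.7-fold higher number from compound 2 to compound 3 (0.44 log units; beyond the scatter), a modest one. That step also exchanged the trifluoromethyl group for the cyclopropyl group, so only part of it should apply here. A smaller move toward a lower number is therefore expected, with an estimated 1.6-fold lower number from compound 3 to compound 4 (0.21 log units; within the scatter). The clearance of compound 4 is estimated at 55 mL/min/kg, within an expected range of 28 mL/min/kg to 105 mL/min/kg.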

Compound 4, clearance: 53 mL/min/kg
Estimate against measurement, compound 4: 1.0-fold (0.02 log units) above; the range from low to high includes it.
By their numbers in this assay, from the lowest: compounds 2, 4 and 3 (each within the scatter of the next, the first and the last beyond it). At a limit, above all of these: compound 1.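

On an aromatic carbon of the five-membered ring, 5-cyclopropylpyridin-2-yl in place of 4-cyclopropylphenyl gives a 1.7-fold lower number from compound 3 to compound 4 (0.23 log units; within the scatter) in this assay and so does not clearly separate the two compounds. With the pyridinyl ring kept, cyclopropyl in place of trifluoromethyl gives a 1.6-fold higher number from compound 2 to compound 4 (0.21 log units; within the scatter) and also stays within the scatter. Each change alone therefore stays within the scatter, while compound 2 and compound 3, which differ by both, stand apart.

On these data alone, whether an amine or a longer chain in place of cyclopropyl would shift clearance remains open. Nothing shown gives a cause for these steps.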